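A few compounds are considered here, and "the series" means these few. Any claim that something is new, unique, unknown or untested is made for them only; others in the source may bear on it.

Compound 1 `COc1ccc2c(C(=O)Nc3cc(F)cc(F)c3)cc(=O)[nH]c2c1`: in a functional assay on KYSE-410 cells (Homo sapiens) for antiproliferative activity, read by MTT assay, with a stated time of 72 h (on this read-out lower numbers stand for stronger inhibition and higher numbers for weaker inhibition), compound 1 reaches only the limit of the assay, > 20000 nM.
Compound 2 `O=C(Nc1cc(F)cc(F)c1)c1cc(=O)[nH]c2cc(O)ccc12`: in this assay compound 2 likewise stops at a limit, > 20000 nM.
Compound 3 `COc1cccc2c(C(=O)Nc3cc(F)cc(F)c3)cc(=O)[nH]c12`: in this assay compound 3 also gives only a limit, > 20000 nM.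

Compound 1 and compound 2 share one core and differ in a single place, (hydrogen in place of methyl on an oxygen on an aromatic ring). The step that the two limits leave unreadable from compound 1 to compound 2 cannot be sized because of the limit of > 20000 nM in this assay, at which 3 of the 3 values shown sit. The core of compound 3 is built from the same atoms as the core of compound 1, joined differently; how the two cores differ is not broken down here.

Compound 4 `O=C(Nc1cc(F)cc(F)c1)c1cc(=O)[nH]c2c(O)cccc12` is not yet measured. It stands to compound 3 exactly as compound 2 stands to compound 1, the same change at the same kind of place: hydrogen in place of methyl on an oxygen on an aromatic ring. Since neither partner of the first pair gave a readable number, the earlier step offers no size to carry over, and the step from compound 3 to compound 4 in this assay is expected to be a step that the limit leaves unreadable from compound 3 to compound 4, resting only on the fact that compound 3 itself sits at the limit, > 20000 nM. Compound 4 is therefore estimated at 25000 nM.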

Compound 4, half-maximal inhibitory concentration: > 20000 nM
Compound 4 was reported as a limit; the forecaster's own chance of this, stated with the estimate: 85%; the middle value lies beyond the limit too.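

Compound 3 and compound 4 both give only a limit, so the step from methoxy to hydroxy between them cannot be read: the limit of > 20000 nM in this assay, at which 4 of the 4 values shown sit.

The compounds shown leave open how strongly any of the four acts in this assay, and whether replacing methoxy with hydroxy changes that activity at all.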